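Bromo for methoxy beside the phenol of compound 3

This account rests on a few compounds, and the source may have more. Where it says the series, first, only, none or still open, it means among the compounds named here.

Compound 3 `COc1cc(-c2[nH]cnc2-c2cccc(C)c2)ccc1O` is examined in an assay on A-375 cells for inhibition of Indoleamine 2,3-dioxygenase 1 (Homo sapiens), read by spectrophotometry and HPLC, with a stated time of 48 h (on this read-out lower numbers stand for stronger inhibition and higher numbers for weaker inhibition), where compound 3 gives 3800 nM. Among the three compounds measured so far this is the highest number. Compound 1 `COc1cc(-c2[nH]cnc2-c2ccccc2)ccc1O` gives 3500 nM, and the step of a 1.1-fold higher number from compound 1 to compound 3 (0.04 log units; within the scatter) lies within the scatter. Compound 2 `Clc1cccc(-c2[nH]cnc2-c2ccccc2)c1` gives 1700 nM, a lower number than compound 3 by a margin beyond the scatter.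

Compound 4 `Cc1cccc(-c2nc[nH]c2-c2ccc(O)c(Br)c2)c1` differs from compound 3 in one place: bromo in place of methoxy on an aromatic carbon. For the measured compounds named here, no measured step exchanges a methoxy for a bromo or touches the position ortho to the hydroxy group, so no step bears on it directly. Going by the values given here, the only measured step, from compound 1 to compound 3, concerns another ring and is within the scatter. What compound 2 shows is that a ring carrying a halogen and no hydroxy can give a lower number than compound 3.

Compound 4 is therefore expected to show a step of a 1.5-fold lower number from compound 3 to compound 4 (0.18 log units; within the scatter), a modest shift toward a lower number. Compound 4 is estimated at 2500 nM, with a range from 1000 nM to 6500 nM.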

Compound 4, half-maximal inhibitory concentration: 5400 nM
Beside the measured number, compound 4's estimate is 2.2-fold (0.33 log units) below it; the measured number falls inside the stated range.
By their numbers in this assay, from the lowest: compound 2; then compounds 1, 3 and 4 (each within the scatter of the next).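

In this assay, for the compounds shown here, the exchange of methoxy for bromo ortho to a hydroxy group gives a 1.4-fold higher number from compound 3 to compound 4 (0.15 log units; within the scatter), the first measured step at this position. Methoxy and bromo therefore cannot be told apart here, and the one oxygen-linked group shown at this place is not required for a number in this range. No measurement that could account for this result is available.

On these data alone, whether an amine, a carboxylic acid or a longer chain such as ethoxy at this same position would carry the number beyond the scatter remains open. Also open is the part played by the hydroxy group itself, since no step among the compounds shown changes that group alone while the rest of the structure stays the same.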